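Chromone Ethers with Basic Side Chains at a Sigma Receptor

The compounds below may be only part of what the source reports. "The series", "measured", "known", "first", "only" and "open" are said of these compounds alone.

Two chromone ethers carrying a dimethylamino chain have been characterised so far. Compound 1 `CN(C)CCCCCCOc1ccc2oc(-c3ccccc3)cc(=O)c2c1` gives 432 nM in an assay on isolated protein (Cavia porcellus) with Sigma non-opioid intracellular receptor 1 (Homo sapiens) as the target, read by radioligand binding; on this read-out higher numbers stand for weaker inhibition and lower numbers for stronger inhibition. Compound 2 `CN(C)CCCCCCCCCCOc1ccc2oc(-c3ccccc3)cc(=O)c2c1` gives 297 nM in this assay, and the step of a 1.5-fold lower number from compound 1 to compound 2 (0.16 log units; within the scatter) shows that lengthening the chain leaves the number where it was. Compound 2 thus stands beside compound 1 with nothing separating the two beyond the scatter.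

Compound 3 `O=c1cc(-c2ccccc2)oc2ccc(OCCCCCCN3CCC(O)CC3)cc12` is the next member: 4-hydroxypiperidin-1-yl in place of 4-(dimethylamino)butyl on a saturated chain carbon, six bonds along the chain from an oxygen on an aromatic ring. For the measured compounds named here, no measured step bears directly on this replacement; the only step available, a 1.5-fold lower number from compound 1 to compound 2 (0.16 log units; within the scatter), concerns chain length alone and was within the scatter. In the absence of a relevant precedent, the change is expected to give a 1.0-fold higher number from compound 2 to compound 3 (0.00 log units; within the scatter), with no direction favoured beyond the scatter. Compound 3 is therefore estimated at 300 nM in this assay, with a range from 100 nM to 900 nM.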

Compound 3, half-maximal inhibitory concentration: 100 nM
Beside the measured number, compound 3's estimate is 3.0-fold (0.48 log units) above it; the range from low to high includes it.
By their numbers in this assay, from the lowest: compound 3; then compounds 2 and 1 (each within the scatter of the next).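

For the compounds shown here, putting 4-hydroxypiperidin-1-yl in place of the dimethylamino end of the chain is the first change here to move the number in this assay beyond the scatter: the chain stays the same in a 4.3-fold lower number from compound 1 to compound 3 (0.64 log units; beyond the scatter), and the comparison with the longer chain gives a 3.0-fold lower number from compound 2 to compound 3 (0.47 log units; beyond the scatter). Lengthening the chain had not separated compound 1 from compound 2, whereas this change to the end group places compound 3 lowest of the three, with its steps to both others beyond the scatter. Nothing available explains this difference.

The hydroxyl and the ring enter together, so the compounds shown do not separate their contributions; a plain piperidine or a morpholine on the same chain would bear on this. They also leave open what 4-hydroxypiperidin-1-yl gives on the longer chain of compound 2.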